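The source may hold more compounds than are shown below. What is called first, only, known or untested is meant among the compounds shown, and "the series" means these compounds.

Working notes on the series. Compound 1 `Cc1ccccc1Cn1cc(COc2ccc3c(=O)ccoc3c2)nn1` carries a methyl on the benzyl ring of the shared core. In an ADME assay on L02 cells (Homo sapiens) for cytotoxicity, read by MTT assay, with a stated time of 48 h (on this read-out lower numbers stand for stronger inhibition and higher numbers for weaker inhibition), compound 1 gives > 300000 nM, which is a limit of the assay and not a number. Compound 2 `O=c1ccoc2cc(OCc3cn(Cc4ccccc4Cl)nn3)ccc12` has chloro in place of methyl; in this assay compound 2 gives > 300000 nM, again a limit. Compound 3 `O=c1ccoc2cc(OCc3cn(Cc4ccccc4F)nn3)ccc12` has fluoro in place of methyl; in this assay compound 3 gives > 300000 nM, also a limit. All three values sit at the same point (the limit of > 300000 nM in this assay, at which 3 of the 3 values shown sit), so the steps a step that the two limits leave unreadable from compound 1 to compound 2, a step that the two limits leave unreadable from compound 1 to compound 3 and a step that the two limits leave unreadable from compound 2 to compound 3 have no readable size. On these numbers compound 3 stands at the limit, indistinguishable from compound 1 and compound 2.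

Compound 4 `COc1ccc(Cn2cc(COc3ccc4c(=O)ccoc4c3)nn2)cc1` differs from compound 3 by 4-methoxyphenyl in place of 2-fluorophenyl on a saturated chain carbon bound to an aromatic nitrogen. For the measured compounds named here, none of the measured steps bears a number on this change: each runs between two limits and stays unreadable. The expected step from compound 3 to compound 4 is a number no higher from compound 3 to compound 4 (the limit leaves the size open), that is no readable change, with compound 4 most probably landing once more at the limit. Compound 4 is estimated in this assay at 300000 nM, with a range from 150000 nM to 600000 nM.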

Compound 4, half-maximal inhibitory concentration: > 300000 nM
Compound 4: only a limit was reported (the forecaster's own chance of this, stated with the estimate: 85%); the middle value lies on the limit itself.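

For the compounds shown here, compound 4 sits at the limit of the assay, as do compound 1, compound 2 and compound 3, so none of its steps to those three can be read and no new step emerges: the limit of > 300000 nM in this assay, at which 4 of the 4 values shown sit. The compounds shown leave open whether these four differ at all in this assay, as none carries a readable number.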